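Swapping a Pyridine for Methoxy on the Amide Nitrogen

The compounds below may be only part of what the source reports. "The series", "measured", "known", "first", "only" and "open" are said of these compounds alone.

In an assay on HEK293 cells for agonist activity at transient receptor potential cation channel subfamily M member 8 (Homo sapiens), read by fluorescence and calcium flux, with a stated time of 15 min (a higher number here means that more compound is needed for the effect, a lower number that less compound is needed), compound 1 `Cc1ccc(OCC(=O)N(Cc2cccs2)c2cccnc2)cc1` gives 198 nM, the lower of the two numbers in hand; compound 2 `CCN(Cc1cccs1)C(=O)c1cc2cc(C)ccc2s1`, built on a different core, gives 1600 nM, a clearly weaker result. Compound 3 `CON(Cc1cccs1)C(=O)COc1ccc(C)cc1` is a close relative of compound 1 with a single change: methoxy in place of pyridin-3-yl on an amide-type nitrogen. Among the measured compounds shown here, no measured pair shows this kind of swap, so any forecast rests on compound 1 alone. The change is expected to cost some activity, with a 4.0-fold higher number from compound 1 to compound 3 (0.61 log units; beyond the scatter) expected to lie somewhat beyond the usual scatter. Compound 3 is therefore estimated at 800 nM, within a range of 200 nM to 3200 nM.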

Compound 3, half-maximal effective concentration: 10 nM
Estimate against measurement, compound 3: 80-fold (1.90 log units) above; the whole stated range lies above it.
By their numbers in this assay, from the lowest: compound 3; then compound 1; then compound 2.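

On the amide-type nitrogen, the pyridin-3-yl ring is not required for activity in this assay: putting methoxy in its place gives a 20-fold lower number from compound 1 to compound 3 (1.30 log units; beyond the scatter), a large step. This position therefore responds strongly to the group it carries, and a small group with no ring can serve there. Nothing available explains the gain. As far as these compounds go, whether ethoxy or a longer alkoxy chain on this nitrogen would hold the activity remains open, as does whether methoxy would have a similar effect on the core of compound 2.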